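Ethyl added to the fused ring of compound 2

The compounds below may be only part of what the source reports. "The series", "measured", "known", "first", "only" and "open" are said of these compounds alone.

Of the compounds shown here, two have been measured in a functional assay on Ca9-22 cells (Homo sapiens) for inhibition, read by wound healing assay, with stated times of 2 h and 16 h, tested at 2 uM; on this read-out higher numbers stand for more inhibition at the one concentration tested (going by the name of the read-out) and lower numbers for less inhibition. Compound 1 `CCc1ccc2nc(-c3ccc(-n4nnc5ccccc54)c(C)c3)sc2c1` gives 70.1% in this assay. Compound 2 `COc1ccc2c(c1)nnn2-c1ccc(-c2nc3ccccc3s2)cc1C` gives 18.5% in this assay, the lower of the two numbers; the gap to compound 1 lies beyond the scatter, but compound 1 and compound 2 differ in more than one place, so no single step can be read from that pair.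

Compound 3 `CCc1ccc2nc(-c3ccc(-n4nnc5cc(OC)ccc54)c(C)c3)sc2c1` has not yet been measured. It differs from compound 2 by ethyl in place of hydrogen on an aromatic carbon, on an aromatic carbon of a six-membered aromatic ring of carbon only, part of a fused system of two rings, meta to a fused ring and para to a fused ring. An ethyl at this place is also present in compound 1, whose 70.1% is the higher number, so a step upward from compound 2 is expected, likely beyond the scatter, though its size is uncertain. The step from compound 2 to compound 3 in this assay is estimated at a number 23.5 percentage points higher from compound 2 to compound 3 (beyond the scatter). For compound 3 the expected value in this assay is 42%, with a range from 18% to 66%.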

Compound 3, a percentage reported as inhibition, at one concentration (the size of the read-out at that concentration, not a potency): 31.1%
The estimate for compound 3 lay 10.9 percentage points above the measured number; the measured number falls inside the stated range.
By their numbers in this assay, from the lowest: compound 2; then compound 3; then compound 1.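

In this assay, among the compounds shown here, the ethyl on this aromatic carbon of the fused ring gives a number 12.6 percentage points higher from compound 2 to compound 3 (beyond the scatter) as a modest gain, the first single-place reading at this position. Compound 3 also isolates the methoxy group, with a number 39 percentage points lower from compound 1 to compound 3 (beyond the scatter) as a large step, so with ethyl held in place, methoxy accounts for a loss that the first pair could not separate. Ethyl thus recovers only part of the gap to compound 1 while methoxy remains, and no supporting data bear on why.

Whether ethyl would give a step of similar size without methoxy stays open, since the compounds shown offer no pair for that comparison. Also open, from the compounds shown here alone, is how a longer chain such as propyl, an amine or a carboxylic acid would read at the ethyl position.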